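From Fluoro to Sulfanyl: an Estimate for Compound 3

A few compounds are considered here, and "the series" means these few. Any claim that something is new, unique, unknown or untested is made for them only; others in the source may bear on it.

Of the compounds shown here, two have been measured in an assay for displacement of a labelled ligand from Adrenergic receptor alpha-1 (Homo sapiens); a lower number here means a stronger inhibitor, a higher number a weaker inhibitor. Compound 2 `Cn1c(=O)cnn(CCCCN2CCN(c3ccccc3F)CC2)c1=O` gives 9.73 nM in this assay, the lowest of the two numbers. Among the measured compounds shown here, its only neighbour, compound 1 `CN(C)c1ccccc1N1CCN(CCCCn2ncc(=O)n(C)c2=O)CC1`, gives 350 nM in this assay. For the measured compounds named here, the single measured step, a 36-fold lower number from compound 1 to compound 2 (1.56 log units; beyond the scatter), is large, and it shows that the group at this position of the shared core can move the number a long way.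

Compound 3 `Cn1c(=O)cnn(CCCCN2CCN(c3ccccc3S)CC2)c1=O` has not yet been measured. It differs from compound 2 by sulfanyl in place of fluoro on an aromatic carbon. Going by the values given here, no measured step concerns sulfanyl, so the step from compound 1 to compound 2 bears on it only in showing that this position is sensitive to change; which way sulfanyl pushes cannot be read from the data. Given that uncertainty, compound 3 is expected to give a somewhat higher number than compound 2, an estimated step of a 3.1-fold higher number from compound 2 to compound 3 (0.49 log units; beyond the scatter). Compound 3 is therefore estimated at 30 nM in this assay, with a range from 8 nM to 120 nM.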

Compound 3, inhibition constant: > 10000 nM
Compound 3 gave a limit, no number; the forecaster's own chance of this, stated with the estimate: 5%; middle value at least 330-fold (2.52 log units) away from the limit.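

In this assay compound 3 reaches a limit of the assay, not a number: the limit of > 10000 nM in this assay, at which 1 of the 3 values shown sits. The change of sulfanyl for fluoro gives an at least 1000-fold higher number from compound 2 to compound 3 (3.01 log units; beyond the scatter), and the change of sulfanyl for dimethylamino gives an at least 28-fold higher number from compound 1 to compound 3 (1.45 log units; beyond the scatter), so among the three groups shown at this place, sulfanyl goes with the highest number, above both fluoro and dimethylamino. The earlier pair showed only that this position is sensitive, whereas this result shows that swapping one heavy atom for one heavy atom, a fluorine for a sulfur, while a hydrogen-bond donor and a hydrogen-bond acceptor enter, is enough to take the number up to the limit of the assay.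

The compounds shown leave open how far beyond the limit compound 3 truly lies, so the real size of both steps remains unknown. They also leave open whether the sulfur itself or the hydrogen on it goes with this change, a question that a methylthio group or a hydroxyl group at the same place could help to separate.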